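Nitrogen substituent series: working notes toward compound 4

A few compounds are considered here, and "the series" means these few. Any claim that something is new, unique, unknown or untested is made for them only; others in the source may bear on it.

Compound 1 `CCOC(=O)c1ccc(-c2nn(C)c3ccccc23)cc1` — in a functional assay on cells (Platelet, Homo sapiens) for inhibition (on this read-out lower numbers stand for stronger inhibition and higher numbers for weaker inhibition), compound 1 gives > 10000 nM, which is a limit of the assay and not a number.
Compound 2 `CCOC(=O)c1ccc(-c2nn(Cc3ccccc3OC)c3ccccc23)cc1` — in this assay compound 2 gives > 10000 nM, again a limit.
Compound 3 `CCOC(=O)c1ccc(-c2nn(Cc3ccccn3)c3ccccc23)cc1` — in this assay compound 3 gives > 10000 nM, also a limit.

Compound 3 thus stands at the limit in this assay, and the two other compounds sit at the same limit (the limit of > 10000 nM in this assay, at which 3 of the 3 values shown sit). None of the steps among the measured compounds can be read: a step that the two limits leave unreadable from compound 1 to compound 2, a step that the two limits leave unreadable from compound 1 to compound 3 and a step that the two limits leave unreadable from compound 2 to compound 3 are all of unknown size.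

Compound 4 `CCOC(=O)c1ccc(-c2nn(-c3ccco3)c3ccccc23)cc1` is the next change: furan-2-yl in place of (pyridin-2-yl)methyl on an aromatic nitrogen. Within the data shown here, all three measured steps concern the group on the saturated chain carbon bound to the aromatic nitrogen, so they bear on the same region of the structure, but each is unreadable, and no measured step places a group directly on the aromatic nitrogen. There is therefore no readable step to build on, and the three limits give no hint of inhibition from any variation in this region.

Compound 4 is accordingly expected to remain at or near the limit in this assay. For compound 4 the estimated value is 15000 nM, expected to fall between 5000 nM and 50000 nM. The step expected is a step that the limit leaves unreadable from compound 3 to compound 4, that is, none beyond the scatter.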

Compound 4, half-maximal inhibitory concentration: > 10000 nM
Compound 4 ended at the assay's limit; the forecaster's own chance of this, stated with the estimate: 80%; the middle value lies beyond the limit too.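

In this assay compound 4 gives > 10000 nM as a limit of the assay and not a number. No step linking compound 4 to compound 1, compound 2 or compound 3 can be read, and all four compounds share one limit: the limit of > 10000 nM in this assay, at which 4 of the 4 values shown sit.

The compounds shown leave open whether any group on the aromatic nitrogen of the shared core gives measurable inhibition in this assay and how far each compound lies past the limit.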